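Methylating the pyrrole nitrogen: a cytotoxicity expectation

The source may hold more compounds than are shown below. What is called first, only, known or untested is meant among the compounds shown, and "the series" means these compounds.

Of the compounds shown here, two have been measured in an ADME assay on Vero cells (Chlorocebus sabaeus) for cytotoxicity, read by MTT assay, with a stated time of 72 h; on this read-out lower numbers stand for stronger inhibition and higher numbers for weaker inhibition. Compound 1 (`COc1cccc(OC)c1-c1nnc(-c2cc([N+](=O)[O-])cn2C)o1`) carries a methyl on the aromatic nitrogen of its nitro-bearing five-membered ring, and in this assay compound 1 gives 177000 nM. Compound 2 (`O=[N+]([O-])c1c[nH]c(-c2nnc(Cc3ccc(F)c4ccccc34)o2)c1`) has a free aromatic nitrogen in that ring and a different group on the other side of the shared core, and in this assay compound 2 gives 229000 nM. The two values lie within the usual scatter of each other, so compound 2 stands together with compound 1 at the weak end of the read-out, with no order between them that the data support.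

Compound 3 (`Cn1cc([N+](=O)[O-])cc1-c1nnc(Cc2ccc(F)c3ccccc23)o1`) differs from compound 2 in one place: methyl in place of hydrogen on an aromatic nitrogen. Going by the values given here, no measured pair isolates this change, so the expectation rests on the two numbers above. Compound 1, which already carries the methyl, gives 177000 nM, within the scatter of compound 2, and the step from compound 2 to compound 3 is therefore expected to be a 1.1-fold lower number from compound 2 to compound 3 (0.06 log units; within the scatter), none beyond the scatter. Compound 3 is estimated at 200000 nM, with a range from 100000 nM to 400000 nM.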

Compound 3, half-maximal inhibitory concentration: 119000 nM
Compound 3: the middle estimate sits 1.7-fold (0.23 log units) above what was measured, within the range that was stated.
By their numbers in this assay, from the lowest: compounds 3, 1 and 2 (each within the scatter of the next).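

Going by these compounds alone, the pair of compound 2 and compound 3 isolates the methyl on the aromatic nitrogen, which the earlier compounds could not do because they differ in more than one place. In this assay, the change gives a 1.9-fold lower number from compound 2 to compound 3 (0.28 log units; within the scatter), which lies within the scatter, so at this position of the five-membered aromatic ring, methyl in place of hydrogen makes no difference that this read-out can separate, at least with the group that compound 2 and compound 3 share on the other side of the core. No available measurement offers an explanation for this result.

The compounds shown leave open whether a larger group on the same nitrogen, such as an ethyl group, a longer chain or a chain ending in an amine or a carboxylic acid, would also stay within the scatter of compound 2. They also leave open whether the methyl would behave in the same way with the other group carried by compound 1, whose counterpart with hydrogen on that nitrogen is not among them.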